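Pyridin-4-yl in Place of 3-Chlorophenyl on a Shared Core

The source may report more compounds than this note shows. Statements on the series, on what has been measured and on what is new or still open speak of the compounds shown alone.

Going by the values given here, compound 2 `CCOC(=O)c1c(C)[nH]c(=O)c(C#N)c1-c1cccc(Cl)c1` was tested in a functional assay on aorta (Rattus norvegicus) for inhibition (a higher number here means a larger maximal response, a lower number a smaller maximal response), where compound 2 gives 97%, the lowest of the two numbers known; its nearest neighbour is compound 1 `CCOC(=O)c1c(C)[nH]c(=O)c(C#N)c1-c1ccco1`, which gives 100%. Among the compounds with values here, the one known step, a number 3 percentage points lower from compound 1 to compound 2 (within the scatter), swapped one aromatic group for another and left the response essentially unchanged. Compound 3 `CCOC(=O)c1c(C)[nH]c(=O)c(C#N)c1-c1ccncc1` differs from compound 2 in this way: pyridin-4-yl in place of 3-chlorophenyl on an aromatic carbon. Within the data shown here, since the only comparable swap stayed within the scatter, no step beyond the scatter is expected here, and for compound 3 a response of 95% (range 78% to 105%) is estimated, which means the expected step of a number 2 percentage points lower from compound 2 to compound 3 (within the scatter).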

Compound 3, largest response reached (reported as efficacy), in percent of the reference or control that the assay uses: 85.5%
Compound 3: the middle estimate sits 9.5 percentage points above what was measured; the range from low to high includes it.
By their numbers in this assay, from the lowest: compound 3; then compounds 2 and 1 (each within the scatter of the next).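

In this assay the change to pyridin-4-yl gives a number 11.5 percentage points lower from compound 2 to compound 3 (beyond the scatter) and also a number 14.5 percentage points lower from compound 1 to compound 3 (beyond the scatter), and both steps lie beyond the scatter. This position therefore does not accept every aromatic group equally, which the swap between compound 1 and compound 2 could not show. Nothing measured here explains the loss of response. Still open, going by these compounds, is how the response would change with an amine or a carboxylic acid on the phenyl ring, or with pyridin-3-yl in place of pyridin-4-yl.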